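Swapping a nitrile for a methylsulfonyl on the aryl ether

This account rests on a few compounds, and the source may have more. Where it says the series, first, only, none or still open, it means among the compounds named here.

Measured so far:
- compound 1 `Cc1cc(COc2ccccc2Cl)nc(-c2ccccn2)n1`: 316 nM
- compound 2 `COc1ccc(OCc2cc(C)nc(-c3ccccn3)n2)cc1`: 7940 nM
- compound 3 `Cc1cc(COc2ccc(C#N)cc2)nc(-c2ccccn2)n1`: 31600 nM

All three share a common core and differ only in the substituent on the aryl ether ring. In a functional assay on cells for antagonist activity at Free fatty acid receptor 1 (Homo sapiens), read by TR-FRET and inositol phosphate accumulation, with a stated time of 2 h (a higher number here means a weaker inhibitor, a lower number a stronger inhibitor), compound 1 gives 316 nM. Compound 2 gives 7940 nM, and compound 3 gives 31600 nM, the highest number of the three, beyond the scatter from both others.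

Among the compounds with values here, the only single-place step among the measured compounds is a 4.0-fold higher number from compound 2 to compound 3 (0.60 log units; beyond the scatter), the cyano in place of methoxy on an aromatic carbon. The new compound 4 `Cc1cc(COc2ccc(S(C)(=O)=O)cc2)nc(-c2ccccn2)n1` is built from compound 3 by methylsulfonyl in place of cyano on an aromatic carbon. Within the data shown here, no measured step tests this exact change, so the expectation rests on compound 3 and the direction of a 4.0-fold higher number from compound 2 to compound 3 (0.60 log units; beyond the scatter). Compound 4 is therefore expected to stay near compound 3 or drift somewhat higher in this assay, with an estimated step of a 1.4-fold higher number from compound 3 to compound 4 (0.15 log units; within the scatter). The estimate for compound 4 is 45000 nM, with a range from 12000 nM to 160000 nM.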

Compound 4, half-maximal inhibitory concentration: > 39800 nM
Compound 4: a limit, no number; the forecaster's own chance of this, stated with the estimate: 40%; the middle value is on the limit's open side.
By their numbers in this assay, from the lowest: compound 1; then compound 2; then compound 3. At a limit, above all of these: compound 4.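

In this assay compound 4 gives > 39800 nM, which is a limit of the assay and not a number. Swapping cyano for methylsulfonyl gives an at least 1.2-fold higher number from compound 3 to compound 4 (0.10 log units; that floor lies within the scatter), and since this is only a floor, the data cannot place these two groups in order at this position. Against methoxy, the same swap to methylsulfonyl gives an at least 5.0-fold higher number from compound 2 to compound 4 (0.70 log units; beyond the scatter), so at this place on the aryl ether ring, para to a large group, a second group now joins cyano in giving a weaker inhibitor than methoxy.

On these data alone, how far the true value of compound 4 lies past its limit stays open. Also open, as far as these compounds go, is how an amine, a carboxylic acid or a longer ether chain at this same place would compare with methoxy.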